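Compound 3 and a swap to a benzyl amide

The compounds below may be only part of what the source reports. "The series", "measured", "known", "first", "only" and "open" are said of these compounds alone.

- compound 1 `COc1ccc2c(=O)c(/C=C/C(=O)Nc3cccc(Cl)c3)coc2c1`: 11900 nM
- compound 2 `O=C(/C=C/c1coc2cc(O)ccc2c1=O)NCc1ccccc1`: > 100000 nM (a limit)
- compound 3 `COc1ccc2c(=O)c(/C=C/C(=O)Nc3ccccc3Cl)coc2c1`: 22400 nM

All three results come from a functional assay on HeLa cells (Homo sapiens) for inhibition, read by MTT assay, with a stated time of 48 h; on this read-out higher numbers stand for weaker inhibition and lower numbers for stronger inhibition. Compound 3, at 22400 nM, cannot be told apart from compound 1, its nearest neighbour: a 1.9-fold higher number from compound 1 to compound 3 (0.27 log units; within the scatter). Compound 2 has no exact number, only a limit.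

The next compound is compound 4 `COc1ccc2c(=O)c(/C=C/C(=O)NCc3ccc(F)cc3)coc2c1`. It places 4-fluorobenzyl in place of 2-chlorophenyl on an amide-type nitrogen.

Within the data shown here, the single measured step that changes only this group, a 1.9-fold higher number from compound 1 to compound 3 (0.27 log units; within the scatter), merely swaps one chlorophenyl for another, so it offers weak guidance. Compound 2 also carries a benzyl-type group there, but its core differs too, and its > 100000 nM is a limit. On that slim basis, a modest move towards a higher number is expected, with much uncertainty. The expected change is a 1.6-fold higher number from compound 3 to compound 4 (0.19 log units; within the scatter). Compound 4 is estimated at 35000 nM, with an expected range from 11000 nM to 110000 nM.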

Compound 4, half-maximal inhibitory concentration: > 100000 nM
Compound 4: only a limit was reported; the forecaster's own chance of this, stated with the estimate: 25%; middle value at least 2.8-fold (0.45 log units) from the limit.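

With 4-fluorobenzyl on the amide-type nitrogen, this assay shows a clear weakening of inhibition: an at least 4.4-fold higher number from compound 3 to compound 4 (0.64 log units; beyond the scatter), and an at least 8.4-fold higher number from compound 1 to compound 4 (0.92 log units; beyond the scatter). Both steps lie beyond the scatter, whereas the earlier swap between the two chlorophenyl groups, a 1.9-fold higher number from compound 1 to compound 3 (0.27 log units; within the scatter), lay within it, so this position does respond to a change of group. The value of compound 4 is a limit and not a number, so both steps give only the smallest possible size of the change, and the result sits at a ceiling shared with one other compound: the limit of > 100000 nM in this assay, at which 2 of the 4 values shown sit.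

The compounds shown do not separate the effect of the benzyl link from that of fluorine replacing chlorine. They also leave open how the shared core would fare with an unsubstituted phenyl group or a longer chain such as 2-phenylethyl on this nitrogen.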